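A few compounds are considered here, and "the series" means these few. Any claim that something is new, unique, unknown or untested is made for them only; others in the source may bear on it.

In a functional assay on HCT-116 cells (Homo sapiens) for cytotoxicity, read by MTT assay, with a stated time of 72 h (a lower number here means a stronger inhibitor, a higher number a weaker inhibitor), compound 1 (`O=C1c2c[n+]([O-])c3ccccc3c2C(=O)c2c1c1ccccc1n2CCCCn1ccnc1`) gives 240 nM in this test, compound 2 (`O=C1c2c[n+]([O-])c3ccccc3c2C(=O)c2c1c1ccccc1n2Cc1cn(CC(O)CO)nn1`) gives 250 nM and compound 3 (`O=C1c2c[n+]([O-])c3ccccc3c2C(=O)c2c1c1ccccc1n2CCN1CCCC1`) gives 270 nM on the same scale. Compound 3 stands level with the other two: the data give a 1.1-fold higher number from compound 1 to compound 3 (0.05 log units; within the scatter) and a 1.1-fold higher number from compound 2 to compound 3 (0.03 log units; within the scatter) and neither step separates them.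

Compound 4 (`O=C1c2c[n+]([O-])c3ccccc3c2C(=O)c2c1c1ccccc1n2CCCCN1CCNCC1`) keeps the shared core and changes one group (2-(piperazin-1-yl)ethyl in place of pyrrolidin-1-yl on a saturated chain carbon, two bonds along the chain from an aromatic nitrogen) so that 2-(piperazin-1-yl)ethyl stands in place of pyrrolidin-1-yl on a saturated chain carbon, two bonds along the chain from an aromatic nitrogen.

The closest guide is the swap at this same place, a 1.1-fold higher number from compound 1 to compound 3 (0.05 log units; within the scatter) and nothing larger, while the swap in a 1.0-fold higher number from compound 1 to compound 2 (0.02 log units; within the scatter) is just as small. None of the three measured compounds carries piperazine, so this guide is indirect.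

No step beyond the scatter is therefore expected, and the estimated change is a 1.1-fold lower number from compound 3 to compound 4 (0.03 log units; within the scatter) in this assay overall. Compound 4 is expected at 250 nM with an estimated range from 115 nM to 540 nM in this test.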

Compound 4, half-maximal inhibitory concentration: 700 nM
Beside the measured number, compound 4's estimate is 2.8-fold (0.45 log units) below it, and the stated range ends below it.
By their numbers in this assay, from the lowest: compounds 1, 2 and 3 (each within the scatter of the next); then compound 4.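

In this assay, the earlier swaps on this chain moved nothing beyond the scatter, whereas 2-(piperazin-1-yl)ethyl in place of pyrrolidin-1-yl gives a 2.6-fold higher number from compound 3 to compound 4 (0.41 log units; beyond the scatter). The gap holds against the other two groups as well, with a 2.8-fold higher number from compound 2 to compound 4 (0.45 log units; beyond the scatter) and a 2.9-fold higher number from compound 1 to compound 4 (0.46 log units; beyond the scatter), so this position is not indifferent to the group placed on it. No measured evidence here bears on the reason for this step.

The swap read one bond further out takes 2-(pyrrolidin-1-yl)ethyl to 4-(piperazin-1-yl)butyl, so the ring and the chain length change together, and the compounds shown cannot say which of them carries the step. A 4-(pyrrolidin-1-yl)butyl group would separate the two, and a morpholine ring in place of piperazine would show whether the ring's second nitrogen matters.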